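Ethoxy to oxocyclohexyloxy on the shared core

The source may report more compounds than this note shows. Statements on the series, on what has been measured and on what is new or still open speak of the compounds shown alone.

Measured in an assay for inhibition of serine/threonine-protein kinase Sgk1 (Homo sapiens), with stated times of 30 min and 60 min, in the presence of a further agent that is not named here; a higher number here means a weaker inhibitor, a lower number a stronger inhibitor:
compound 1 `CN1CCC(NC(=O)c2cc(-c3ccc(NS(=O)(=O)c4cccc(Cl)c4Cl)cc3)nc3[nH]ncc23)C1`: 21 nM
compound 2 `CN1CC(NC(=O)c2cc(-c3ccc(NS(=O)(=O)c4cccc(Cl)c4Cl)cc3)nc3[nH]ncc23)C1`: < 1 nM, which is a limit of the assay and not a number.
compound 3 `CCOc1nc(-c2ccc(NS(=O)(=O)c3cc(Cl)ccc3F)cc2)nc2[nH]nc(C)c12`: 183 nM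

Among the two numbers shown, compound 3 holds the highest; the nearest is compound 1, which lies beyond the scatter from it. Compound 2 stands at the assay limit (the limit of < 1 nM in this assay, at which 1 of the 3 values shown sits). Compound 4 `Cc1n[nH]c2nc(-c3ccc(NS(=O)(=O)c4cc(Cl)ccc4F)cc3)nc(OC3CCC(=O)CC3)c12` differs from compound 3 in one place: 4-oxocyclohexyl in place of ethyl on an oxygen on an aromatic ring. Among the compounds with values here, the only measured step, an at least 21-fold lower number from compound 1 to compound 2 (1.32 log units; beyond the scatter), concerns a different group at a different place, so it gives no direct guide to the exchange of ethoxy for (4-oxocyclohexyl)oxy; it shows only that a single change within this set can move the number a great deal. Within the data shown here, with no precedent for the change itself, no direction is taken as established, and the expected step of a 1.2-fold lower number from compound 3 to compound 4 (0.09 log units; within the scatter) is set near no change, with a wide range to allow a sizeable move either way. Compound 4 is therefore expected to give about 150 nM in this assay, within 40 nM to 600 nM.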

Compound 4, half-maximal inhibitory concentration: 18 nM
Compound 4: the middle estimate sits 8.3-fold (0.92 log units) above what was measured, outside the stated range (below it).
By their numbers in this assay, from the lowest: compounds 4 and 1 (each within the scatter of the next); then compound 3. At a limit, below all of these: compound 2.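

In this assay, the place on an oxygen on an aromatic ring takes a far bulkier group than ethyl without loss, and the number moves strongly the other way: a 10-fold lower number from compound 3 to compound 4 (1.01 log units; beyond the scatter). Within the data shown here, this is the first reading of how a change at this place acts, and the incoming 4-oxocyclohexyl brings both a six-membered non-aromatic ring of carbon and a hydrogen-bond acceptor, so the place is sensitive to its substituent and a ring on this oxygen is compatible with a number well under that of the ethoxy compound. Among these compounds, nothing measured so far accounts for the size of this step.

Open, on these data alone, is whether the step belongs to the ring itself or to its carbonyl, which a plain cyclohexyl, a 4-hydroxycyclohexyl or a 4-aminocyclohexyl on the same oxygen would separate. Also open, as far as these compounds go, is whether a longer open chain such as butyl would give a similar number, and whether the exchange of ethoxy for (4-oxocyclohexyl)oxy would act the same way with a different sulfonamide aryl group on the shared core.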